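Ethoxy in Place of Fluoro on the Pendant Phenyl

This account rests on a few compounds, and the source may have more. Where it says the series, first, only, none or still open, it means among the compounds named here.

Compound 1 `COc1cc(C(=O)c2sc3ccccc3c2-c2ccc(F)cc2)cc(OC)c1OC` gives 2300 nM in a functional assay on Jurkat cells (Homo sapiens) for antiproliferative activity, read by MTT assay, with a stated time of 72 h (on this read-out lower numbers stand for stronger inhibition and higher numbers for weaker inhibition), the lowest of the two numbers shown. Compound 2 `COc1cc(C(=O)c2sc3ccccc3c2-c2ccc(Cl)cc2)cc(OC)c1OC` gives 3700 nM in this assay, and a 1.6-fold higher number from compound 1 to compound 2 (0.21 log units; within the scatter). Compound 3 `COc1ccc(OC)c(-c2c(C(=O)c3cc(OC)c(OC)c(OC)c3)sc3ccccc23)c1` reaches only > 10000 nM in this assay, a limit rather than a number, (the limit of > 10000 nM in this assay, at which 1 of the 3 values shown sits). The step behind that, an at least 4.3-fold higher number from compound 1 to compound 3 (0.63 log units; beyond the scatter), lies beyond the scatter. Compound 4 `CCOc1ccc(-c2c(C(=O)c3cc(OC)c(OC)c(OC)c3)sc3ccccc23)cc1` differs from compound 1 by ethoxy in place of fluoro on an aromatic carbon. The swap of halogens toward compound 2 bears little on this, but the step toward compound 3 shows that a 2,5-dimethoxyphenyl weakens inhibition, so an oxygen-bearing substituent is the nearer guide. Compound 4 is therefore expected to be somewhat weaker, with a 2.0-fold higher number from compound 1 to compound 4 (0.29 log units; within the scatter). The expected value for compound 4 is 4500 nM, between 1500 nM and 15000 nM.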

Compound 4, half-maximal inhibitory concentration: 4100 nM
Beside the measured number, compound 4's estimate is 1.1-fold (0.04 log units) above it, within the range that was stated.
By their numbers in this assay, from the lowest: compounds 1, 2 and 4 (each within the scatter of the next). At a limit, above all of these: compound 3.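

At this position in this assay, ethoxy cannot be told apart from either halogen, with a 1.8-fold higher number from compound 1 to compound 4 (0.25 log units; within the scatter) and a 1.1-fold higher number from compound 2 to compound 4 (0.04 log units; within the scatter). An oxygen-bearing substituent as such therefore does not bring the loss seen with compound 3, whose entry is a limit and not a number: the limit of > 10000 nM in this assay, at which 1 of the 4 values shown sits. Measured against that limit, the 4-ethoxyphenyl gives an at least 2.4-fold lower number from compound 3 to compound 4 (0.38 log units; beyond the scatter).

The compounds shown leave open whether a longer chain than ethoxy would stay in this range. They also leave open how an amine or a carboxylic acid would read at this position.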